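Removing a Methoxy Group from a Biaryl Sulfonamide

The compounds below may be only part of what the source reports. "The series", "measured", "known", "first", "only" and "open" are said of these compounds alone.

Compound 1 `COc1ccccc1-c1cccc(S(=O)(=O)N2CCC(N3CCC(C)CC3)CC2)c1`: 21 nM
Compound 2 `Cc1noc(C)c1S(=O)(=O)N1CCC(N2CCC(C)CC2)CC1`: > 5000 nM (a limit, not a number)
Compound 3 `COc1ccc(S(=O)(=O)N2CCC(N3CCC(C)CC3)CC2)cc1OC`: 138 nM

Of the compounds shown here, three sharing the same core have been tested in a functional assay on DLD-1 cells (Homo sapiens) for antiproliferative activity, read by CellTiter-Glo, with a stated time of 72 h; on this read-out higher numbers stand for weaker inhibition and lower numbers for stronger inhibition. Compound 1 gives the lowest of the two numbers recorded; compound 3 sits at a higher number, and the gap between the two lies beyond the scatter. Compound 2 is reported only as the limit of > 5000 nM in this assay, at which 1 of the 3 values shown sits, so for it no number exists. Compound 1 and compound 3 differ in more than one place, so their values show a difference without assigning it to any single change.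

Compound 4 `CC1CCN(C2CCN(S(=O)(=O)c3cccc(-c4ccccc4)c3)CC2)CC1` has not yet been measured. It differs from compound 1 by hydrogen in place of methoxy on an aromatic carbon. Within the data shown here, no measured pair in this set isolates such a change, so the expected step is uncertain. A modest move toward a higher number, or none beyond the scatter, seems the most likely outcome. The step expected in this assay is a 2.1-fold higher number from compound 1 to compound 4 (0.33 log units; beyond the scatter). Compound 4 is therefore estimated at 45 nM, with a range from 15 nM to 140 nM.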

Compound 4, half-maximal inhibitory concentration: 2 nM
For compound 4 the middle estimate is 23-fold (1.35 log units) above the measured one; measured number below the stated range.
By their numbers in this assay, from the lowest: compound 4; then compound 1; then compound 3. At a limit, above all of these: compound 2.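

In this assay, among these compounds, taking methoxy off the aromatic carbon ortho to a large group gives an 11-fold lower number from compound 1 to compound 4 (1.02 log units; beyond the scatter), the only step in this set that isolates a change in one place. It shows that the methoxy group at this place is not needed for the low numbers of compound 1, and that the plain phenyl of compound 4 goes with clearly stronger inhibition than the 2-methoxyphenyl group. Nothing given here bears on why this step is so large.

Going by these compounds, whether a methyl group, a hydroxyl group or an amine at the same place would stay close to hydrogen or fall back toward methoxy remains open. So does whether a methoxy group elsewhere on that phenyl ring would change the number by a similar amount.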